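This account rests on a few compounds, and the source may have more. Where it says the series, first, only, none or still open, it means among the compounds named here.

Among the compounds with values here, compound 2 `O=C([C@@H]1C[C@@H]1F)N1CC2CC(C1)N2` holds the lower of the two numbers so far in an assay on SH-EP1 cells for agonist activity at Neuronal acetylcholine receptor; alpha4/beta2 (Homo sapiens), read by FLIPR and calcium flux; a higher number here means that more compound is needed for the effect, a lower number that less compound is needed: compound 2 gives 370 nM, and the nearest neighbour, compound 1 `O=C([C@H]1C[C@H]1F)N1CC2CC(C1)N2`, gives 1500 nM in this assay. Within the data shown here, the one measured step, a 4.1-fold lower number from compound 1 to compound 2 (0.61 log units; beyond the scatter), is a change of drawn configuration alone, and what separates the pair is the fact that one of compounds 1 and 2 is drawn with a defined configuration and the other without, at the place where they differ. Compound 3 `C[C@H]1C[C@H]1C(=O)N1CC2CC(C1)N2` is the next member; the change from compound 2 is methyl in place of fluoro on a saturated ring carbon. Among the measured compounds shown here, no measured step turns on that group: the single step in hand exchanges stereochemistry, not the substituent on the three-membered ring, so it offers neither size nor direction for a fluoro-to-methyl swap. With nothing that bears on the change, compound 3 is expected to show a step of a 1.4-fold higher number from compound 2 to compound 3 (0.13 log units; within the scatter), no movement beyond the scatter, though the range is kept wide to reflect the absence of any guiding step. Compound 3 is therefore estimated at 500 nM in this assay, with a range from 150 nM to 1700 nM.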

Compound 3, half-maximal effective concentration: 5800 nM
Compound 3: the middle estimate sits 12-fold (1.06 log units) below what was measured; the measured number lies above the stated range.
By their numbers in this assay, from the lowest: compound 2; then compound 1; then compound 3.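

The group on the saturated ring carbon of the three-membered ring matters in this assay, and methyl gives a higher number than fluoro against either fluoro compound: a 16-fold higher number from compound 2 to compound 3 (1.20 log units; beyond the scatter), and a 3.9-fold higher number from compound 1 to compound 3 (0.59 log units; beyond the scatter). Both steps lie beyond the scatter, so compound 3 holds the highest number of the three, but the exchange is large when read from compound 2 and modest when read from compound 1, so its size here depends on which fluoro compound serves as the reference. The information in hand concerns drawn configuration only and does not bear on the exchange of fluoro for methyl, so the upward move stays unexplained.

Still open, going by these compounds, is how the number responds to other groups at this ring carbon, such as a hydroxyl, an ethyl or a trifluoromethyl, or to plain hydrogen there, and so whether fluoro is unusual or methyl is. Within the data shown here, also open is how far the configuration of the methyl cyclopropane moves the number, since the only configuration step in hand belongs to the fluoro pair.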